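The source may hold more compounds than are shown below. What is called first, only, known or untested is meant among the compounds shown, and "the series" means these compounds.

Working notes on the series. Among the compounds with values here, in a functional assay on MCF7 cells (Homo sapiens) for cytotoxicity, read by MTT assay, with a stated time of 72 h (a higher number here means a weaker inhibitor, a lower number a stronger inhibitor), compound 1 (`O=C1c2c[n+]([O-])c3ccccc3c2C(=O)c2c1c1ccccc1n2Cc1cn([C@@H]2C[C@H](O)[C@@H](CO)O2)nn1`) gives 110 nM, the lower of the two numbers so far. Compound 2 (`O=C1c2c[n+]([O-])c3ccccc3c2C(=O)c2c1c1ccccc1n2CCN1CCCC1`) gives 320 nM, and that gap lies beyond the scatter. Within the data shown here, the two share a core but carry different side chains, and no single-change step between measured compounds is available to size the next move.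

Compound 3 (`CC1(C)OC[C@H](Cn2cc(Cn3c4c(c5ccccc53)C(=O)c3c[n+]([O-])c5ccccc5c3C4=O)nn2)O1`) keeps the core of compound 1 and changes one group on an aromatic nitrogen of the five-membered aromatic ring with 3 nitrogen: (2,2-dimethyl-1,3-dioxolan-4-yl)methyl in place of 4-hydroxy-5-(hydroxymethyl)oxolan-2-yl ((2,2-dimethyl-1,3-dioxolan-4-yl)methyl in place of 4-hydroxy-5-(hydroxymethyl)oxolan-2-yl on an aromatic nitrogen).

Among the measured compounds shown here, the only guide to how far a different side chain can move the number is compound 2 at 320 nM, set against compound 1 at 110 nM. On that thin basis, a small move towards a higher number is expected, not clearly beyond the scatter: a 1.8-fold higher number from compound 1 to compound 3 (0.26 log units; within the scatter). In this assay, the estimate for compound 3 is 200 nM, with an expected range from 70 nM to 600 nM.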

Compound 3, half-maximal inhibitory concentration: 530 nM
Beside the measured number, compound 3's estimate is 2.7-fold (0.42 log units) below it, within the range that was stated.
By their numbers in this assay, from the lowest: compound 1; then compounds 2 and 3 (each within the scatter of the next).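

In this assay, within the data shown here, the step at this position is the first single-place comparison: (2,2-dimethyl-1,3-dioxolan-4-yl)methyl in place of 4-hydroxy-5-(hydroxymethyl)oxolan-2-yl on an aromatic nitrogen of the five-membered aromatic ring with 3 nitrogen gives a 4.8-fold higher number from compound 1 to compound 3 (0.68 log units; beyond the scatter), so the group on this nitrogen can shift the number even though the core stays the same. Both groups have 8 heavy atoms, so the step occurs with no change in that count, while the group that leaves has 2 hydrogen-bond donors and 3 defined stereocentres and the group that enters has 0 donors and 1 defined stereocentre. These differences travel together in this one pair, and no further measurement bears on the step, which stands without an explanation.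

The compounds shown leave open which of those differences matters, since a single replacement cannot separate them. An open 2,3-dihydroxypropyl chain on the same nitrogen would keep hydroxyl groups without the oxolane ring, and a simple amine or carboxylic acid there would show how far this position tolerates groups of a different kind.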